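A larger side chain on compound 2 in the tail flick test

The source may report more compounds than this note shows. Statements on the series, on what has been measured and on what is new or still open speak of the compounds shown alone.

Three compounds have been measured in a functional assay on the whole organism (Tail, strain ICR) with Mus musculus as the target, in the tail flick test, with a stated time of 30 min, at a dose of 25 umol/kg by the oral route; on this read-out lower numbers stand for a weaker effect and higher numbers for a stronger effect at the one dose given:

compound 1, `O=C(O)[C@@H]1CCCN1C(=O)CN(c1nc(Cl)nc2[nH]cnc12)C1CC1`: 31.5%
compound 2, `C[C@H](NC(=O)CN(c1nc(Cl)nc2[nH]cnc12)C1CC1)C(=O)O`: 48.1%
compound 3, `C[C@H](NC(=O)CN(c1nc(Cl)nc2[nH]cnc12)C1CC1)C(=O)OCc1ccccc1`: 41.2%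

For the measured compounds named here, compound 2 stands at the top of these three numbers, but only one of its two neighbours is clearly separated from it. Its nearest neighbour is compound 3, where the benzyl in place of hydrogen on an oxygen next to a carbonyl group gives a number 6.9 percentage points lower from compound 2 to compound 3 (within the scatter). The furthest is compound 1, where the (1-carboxyethyl)amino in place of 2-carboxypyrrolidin-1-yl on a carbonyl carbon gives a number 16.6 percentage points higher from compound 1 to compound 2 (beyond the scatter).

Compound 4, `N=C(N)NCCC[C@H](NC(=O)CN(c1nc(Cl)nc2[nH]cnc12)C1CC1)C(=O)O`, is not yet measured. It differs from compound 2 by a group of 6 heavy atoms (3 carbon, 3 nitrogen; no ring) in place of a hydrogen atom, on a saturated chain carbon, two bonds along the chain from an amide-type nitrogen and a carbonyl carbon. Neither measured step touches this saturated chain carbon: the step from compound 1 to compound 2 reshapes the part bearing the acid, and the step from compound 2 to compound 3 changes only the oxygen next to the carbonyl group. The nearer of the two, the benzyl change, stayed within the scatter, and the remoter one was modest. On this basis compound 4 is expected to give a step of a number 3.1 percentage points lower from compound 2 to compound 4 (within the scatter), that is none beyond the scatter, in this assay. Compound 4 is therefore estimated at 45%, in the range 25% to 65%.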

Compound 4, a percentage reported as activity, at one dose (the size of the read-out at that dose, not a potency): 45.4%
For compound 4 the middle estimate is 0.4 percentage points below the measured one, within the range that was stated.
By their numbers in this assay, from the lowest: compounds 1, 3, 4 and 2 (each within the scatter of the next, the first and the last beyond it).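

In this assay, the group of 6 heavy atoms (3 carbon, 3 nitrogen; no ring) in place of a hydrogen atom, on a saturated chain carbon, gives a number 2.7 percentage points lower from compound 2 to compound 4 (within the scatter), so this carbon, which neither earlier step touched, carries the group without a change beyond the scatter. Here a lone hydrogen atom and a group with 3 hydrogen-bond donors, 1 hydrogen-bond acceptor and 1 double bond cannot be told apart, at this one dose and time, and the substituent's size alone does not separate the two compounds. No experimental information given here accounts for this outcome.

The compounds shown leave open whether a simple amine, a carboxylic acid or a phenyl ring at the end of a chain on this carbon would also stay within the scatter, and whether a longer chain would do so. They also leave open how the group would read alongside the benzyl on the oxygen next to the carbonyl group, or on the acid-bearing pyrrolidine part of compound 1.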